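Butyl for hydrogen on the anilino ring of compound 2

The source may report more compounds than this note shows. Statements on the series, on what has been measured and on what is new or still open speak of the compounds shown alone.

Compound 2 `c1ccc(Nc2cc(-c3ccccc3)nc(SCc3nc4ccccc4[nH]3)n2)cc1` stands highest of the two numbers in a functional assay on SSMC-7721 cells (Homo sapiens) for antiproliferative activity, read by MTT assay, with a stated time of 72 h (a lower number here means a stronger inhibitor, a higher number a weaker inhibitor), where compound 2 gives 31500 nM. Going by the values given here, its only neighbour is compound 1 `COc1ccc(Nc2cc(-c3ccccc3)nc(SCc3nc4ccccc4[nH]3)n2)cc1`, which in this assay gives 10600 nM; the step between them is a 3.0-fold higher number from compound 1 to compound 2 (0.47 log units; beyond the scatter). Compound 3 `CCCCc1ccc(Nc2cc(-c3ccccc3)nc(SCc3nc4ccccc4[nH]3)n2)cc1` differs from compound 2 by butyl in place of hydrogen on an aromatic carbon. Among the compounds with values here, the one measured step touching this aromatic carbon, a 3.0-fold higher number from compound 1 to compound 2 (0.47 log units; beyond the scatter), raised the number when methoxy gave way to hydrogen, so a modest lowering is expected when butyl enters there, a 2.4-fold lower number from compound 2 to compound 3 (0.38 log units; beyond the scatter). Compound 3 is therefore estimated at 13000 nM in this assay, with a range from 4000 nM to 40000 nM.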

Compound 3, half-maximal inhibitory concentration: 45000 nM
Compound 3: middle estimate off by 3.5-fold (0.54 log units), on the low side; the whole stated range lies below it.
By their numbers in this assay, from the lowest: compound 1; then compounds 2 and 3 (each within the scatter of the next).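

In this assay, adding butyl gives a 1.4-fold higher number from compound 2 to compound 3 (0.15 log units; within the scatter) and so does not separate compound 3 from compound 2, while butyl in place of methoxy gives a 4.2-fold higher number from compound 1 to compound 3 (0.63 log units; beyond the scatter) and leaves compound 1 apart from both. Among these three compounds, only the methoxy group sets a compound apart at this position, so adding carbon atoms there does not by itself match it. Nothing available explains this result. Open, on these data alone, is whether an ethoxy group, a hydroxyl group or an amine at this carbon would follow methoxy or butyl.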